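The compounds below may be only part of what the source reports. "The series", "measured", "known", "first", "only" and "open" are said of these compounds alone.

Measured so far in an in vitro ADME assay on microsomes from liver (Homo sapiens) for metabolic stability; on this read-out higher numbers stand for fast clearance and lower numbers for slow clearance:
- compound 1 `CC(C)NC(=O)[C@H]1CC[C@@H](n2/c(=N/C(=O)c3ccc(C#N)c(F)c3)[nH]c3ccc(CN4CCC(C(C)(C)O)CC4)cc32)CC1`: 132 mL.min-1.g-1
- compound 2 `CC(C)NC(=O)[C@H]1CC[C@@H](n2/c(=N/C(=O)c3ccc(F)cc3)[nH]c3ccc(CN4CCCCC4)cc32)CC1`: 302 mL.min-1.g-1

In this assay compound 1 gives 132 mL.min-1.g-1, the lowest of the two numbers in hand. Its nearest neighbour, compound 2, gives 302 mL.min-1.g-1, a gap beyond the scatter. The two compounds differ in more than one place, so that gap is not read as the effect of any single change.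

The next step starts from compound 1 and leaves everything outside the carbonyl substituent as it is. Compound 3 `CC(C)NC(=O)[C@H]1CC[C@@H](n2/c(=N/C(=O)c3cccnc3)[nH]c3ccc(CN4CCC(C(C)(C)O)CC4)cc32)CC1` carries pyridin-3-yl in place of 4-cyano-3-fluorophenyl on a carbonyl carbon. Among the compounds with values here, the series holds no measured step between compounds that differ in one place, so the expectation for this change is a judgement and not a read-across. In this assay a modest move towards a lower number is expected, most likely not beyond the scatter. The estimated step of a 1.3-fold lower number from compound 1 to compound 3 (0.10 log units; within the scatter) is expected to be of that size. For compound 3 the estimated value is 105 mL.min-1.g-1, with an expected range of 50 mL.min-1.g-1 to 220 mL.min-1.g-1.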

Compound 3, intrinsic clearance in microsomes: 47 mL.min-1.g-1
Estimate against measurement, compound 3: 2.2-fold (0.35 log units) above; measured number below the stated range.
By their numbers in this assay, from the lowest: compound 3; then compound 1; then compound 2.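

In this assay, within the data shown here, the carbonyl substituent is the first place where a single change can be read: pyridin-3-yl in place of 4-cyano-3-fluorophenyl gives a 2.8-fold lower number from compound 1 to compound 3 (0.45 log units; beyond the scatter), with the rest of compound 1 held as it stands. This shows that the read-out responds to this position alone, and that the gap beyond the scatter seen between compound 1 and compound 2 is no longer the only sign of movement in the series; the lower number also needs neither the nitrile nor the fluorine of compound 1, and it comes with fewer heavy atoms in the substituent. Nothing at hand explains why the number falls with this change.

Among these compounds, the single step swaps the whole substituent, so the ring nitrogen of pyridin-3-yl and the loss of the nitrile and the fluorine stay unseparated, a question that a plain phenyl or a pyrimidinyl group on the same carbonyl carbon would bear on. On these data alone, whether the step carries over to other groups outside the carbonyl substituent also stays open, since compound 2 differs from compound 3 in more than one place.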